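Cyano in place of trifluoromethyl across two cores

This account rests on a few compounds, and the source may have more. Where it says the series, first, only, none or still open, it means among the compounds named here.

Compound 1 `COc1cccc2sc(NC(=O)c3ccc(C(F)(F)F)cc3)nc12` and compound 2 `COc1cccc2sc(NC(=O)c3ccc(C#N)cc3)nc12` share one core; compound 3 `COc1ccc2sc(NC(=O)c3ccc(C(F)(F)F)cc3)nc2c1` and compound 4 `COc1ccc2sc(NC(=O)c3ccc(C#N)cc3)nc2c1` share another. The difference between the two cores is not broken down here. In a functional assay on SK-HEP1 cells (Homo sapiens) for antiproliferative activity, read by sulforhodamine B assay (a higher number here means a weaker inhibitor of growth, a lower number a stronger inhibitor of growth), compound 1 gives only a limit of the assay, > 10 ug/mL. Compound 2 likewise reaches only a limit, > 10 ug/mL. Compound 3 too stops at a limit, > 10 ug/mL. The change from compound 1 to compound 2 is cyano in place of trifluoromethyl on an aromatic carbon, and its step is a step that the two limits leave unreadable from compound 1 to compound 2, unreadable because of the limit of > 10 ug/mL in this assay, at which 3 of the 3 values shown sit. The change from compound 3 to compound 4, (cyano in place of trifluoromethyl on an aromatic carbon), is the same change at the same place. Compound 4 is expected to give a step that the limit leaves unreadable from compound 3 to compound 4 because the limit of > 10 ug/mL in this assay, at which 3 of the 3 values shown sit, holds for all three measured compounds. The estimate for compound 4 is 15 ug/mL, between 7 ug/mL and 40 ug/mL.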

Compound 4, concentration for 50% growth inhibition: > 10 ug/mL
Compound 4: no number, only a limit; the forecaster's own chance of this, stated with the estimate: 80%; the middle value is on the limit's open side.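

No step can be read from compound 3 to compound 4, nor from compound 1 to compound 2, because all sit at the same limit: the limit of > 10 ug/mL in this assay, at which 4 of the 4 values shown sit.

The compounds shown leave open whether cyano and trifluoromethyl differ at all in this assay on either core.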